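Notes on compound 3: hydrogen in place of methyl

The source may hold more compounds than are shown below. What is called first, only, known or untested is meant among the compounds shown, and "the series" means these compounds.

compound 1 `Cc1c(OCCCCOc2cccc(C(=O)O)c2)ccc(C(=O)CC2CCCC2)c1O`: 99%
compound 2 `Cc1ccc(C(=O)O)cc1OCCCCOc1ccc(C(=O)CC(C)C)c(O)c1C`: 96%

In an ADME assay on a cell-free system (plasma, Rattus norvegicus) for metabolic stability, read by LC-MS, with a stated time of 60 min, tested at 100 uM (on this read-out lower numbers stand for a less stable compound and higher numbers for a more stable compound), compound 2 gives 96% and lies within the scatter of compound 1. Compound 3 `Cc1c(OCCCCOc2cccc(C(=O)O)c2)ccc(C(=O)CC(C)C)c1O` departs from compound 2 by one change hydrogen in place of methyl on an aromatic carbon with hydrogen in place of methyl on an aromatic carbon, para to a carboxy group. Among the compounds with values here, no measured pair shows this change alone. Compound 1 also carries 3-carboxyphenyl and gives 99% in this assay as well, so no shift beyond the scatter is expected. The expected a number 1 percentage points higher from compound 2 to compound 3 (within the scatter) is small. Compound 3 is estimated at 97% (expected range 88% to 100%).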

Compound 3, percent of the compound remaining: 100%
Compound 3: the middle estimate sits 3 percentage points below what was measured; low and high end bracket the measured number.
By their numbers in this assay, from the lowest: compounds 2, 1 and 3 (each within the scatter of the next).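

Hydrogen in place of methyl on an aromatic carbon, para to a carboxy group, now has a measured pair in this assay: the step reads a number 4 percentage points higher from compound 2 to compound 3 (within the scatter) and is the first direct reading of this change. Isopropyl in place of cyclopentyl on a saturated chain carbon bound to a carbonyl carbon also has its first reading, a number 1 percentage points higher from compound 1 to compound 3 (within the scatter), with the 3-carboxyphenyl group held constant. Nothing available accounts for either step.

Going by these compounds, whether a methoxy group or an amine on that aromatic carbon would give a step beyond the scatter stays open. So does the effect of a longer chain in place of the butylene-length link between the two oxygens of the shared core.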